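This account rests on a few compounds, and the source may have more. Where it says the series, first, only, none or still open, it means among the compounds named here.

Measured compounds:
- compound 1 `CCc1nn(C)c2c1C(c1ccccc1)=NCC(=O)N2`: 2.5 mg/kg
- compound 2 `CCc1nn(C)c2c1C(c1cccc(F)c1)=NCC(=O)N2C`: 10 mg/kg
- compound 3 `Cn1nc(Cl)c2c1NC(=O)CN=C2c1ccccc1`: 40 mg/kg

In a functional assay on the whole organism (strain Holtzman) with Rattus norvegicus as the target (a higher number here means that more compound is needed for the effect, a lower number that less compound is needed), compound 1 gives the lowest of the three numbers; compound 2 gives 10 mg/kg, and compound 3 gives 40 mg/kg. Compound 4 `CCc1nn(C)c2c1C(c1ccccc1Cl)=NCC(=O)N2` has not yet been measured. It differs from compound 1 in one place: chloro in place of hydrogen on an aromatic carbon.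

Among the compounds with values here, the only single change measured so far is a 16-fold higher number from compound 1 to compound 3 (1.20 log units; beyond the scatter), but that change sits on the shared core, not on the phenyl ring, and it swaps an ethyl rather than a hydrogen, so it does not speak to the change at hand. Compound 2 differs from compound 1 in two places at once, so its value gives no clean reading either. A direct guide is therefore missing. With nothing pointing to a large shift, the step of a 1.7-fold lower number from compound 1 to compound 4 (0.22 log units; within the scatter) is expected to stay small, with a slight lean toward a lower number. Compound 4 is estimated at 1.5 mg/kg, within a range of 0.4 mg/kg to 6 mg/kg.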

Compound 4, minimum effective dose: 2.5 mg/kg
Beside the measured number, compound 4's estimate is 1.7-fold (0.22 log units) below it; the measured number falls inside the stated range.
By their numbers in this assay, from the lowest: compounds 1 and 4 (each within the scatter of the next); then compound 2; then compound 3.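

Going from phenyl to 2-chlorophenyl gives no change at the digits printed from compound 1 to compound 4 (within the scatter) in this assay and is the first single change read on this ring rather than on the shared core. Within the data shown here, a chloro on this aromatic carbon, ortho to a large group, therefore leaves the dose needed within normal scatter, whereas the one other single change, chloro in place of ethyl on the core, gives a 16-fold higher number from compound 1 to compound 3 (1.20 log units; beyond the scatter) and shows that the two places do not respond alike. Nothing available here explains this difference.

On these data alone, whether a methoxy, an amine or a carboxylic acid at this same position would also leave the dose level remains open. As far as these compounds go, it is also open whether a chloro on another carbon of this ring would match the result seen here.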